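Bromo in Place of Chloro on Two Related Cores

A few compounds are considered here, and "the series" means these few. Any claim that something is new, unique, unknown or untested is made for them only; others in the source may bear on it.

Measured compounds:
compound 1, `Nc1sc2c(c1C(=O)c1ccc(Cl)c3ccccc13)CCC2`: 0%
compound 2, `Nc1sc2c(c1C(=O)c1ccc(Br)c3ccccc13)CCC2`: 0%
compound 3, `Nc1sc2c(c1C(=O)c1ccc(Cl)c3ccccc13)CCCC2`: 4.8%

Of the compounds shown here, three have been tested in an assay on isolated protein with adenosine receptor A1 (Homo sapiens) as the target, tested at 10 uM; on this read-out higher numbers stand for more inhibition at the one concentration tested (going by the name of the read-out) and lower numbers for less inhibition. In this assay compound 1 gives 0%. Compound 2 is obtained from compound 1 by one change, (bromo in place of chloro on an aromatic carbon), and the step this makes is no change at the digits printed from compound 1 to compound 2 (within the scatter). Compound 3 shares the substituted aromatic ketone of compound 1 but carries a different core; the difference between the two cores is not broken down here. In this assay compound 3 gives 4.8%, a number that lies within the scatter of the values of compound 1 and compound 2, so no order among the three can be drawn.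

Compound 4, `Nc1sc2c(c1C(=O)c1ccc(Br)c3ccccc13)CCCC2`, has not yet been measured. It stands to compound 3 as compound 2 stands to compound 1: the change is bromo in place of chloro on an aromatic carbon, and the surroundings of the place are the same in both pairs, so this is the same change. For compound 4 the step expected from compound 3 is a number 1.8 percentage points lower from compound 3 to compound 4 (within the scatter), and this expectation rests on the earlier step, no change at the digits printed from compound 1 to compound 2 (within the scatter), in which the same change left the read-out where it was. Compound 4 is therefore estimated at 3% in this assay, with a range from -5% to 12%, all of it within the scatter of the values already seen.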

Compound 4, a percentage reported as inhibition, at one concentration (the size of the read-out at that concentration, not a potency): 12%
The estimate for compound 4 lay 9 percentage points below the measured number, and the stated range covers the measured number.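

In this assay, bromo in place of chloro on the second core gives a number 7.2 percentage points higher from compound 3 to compound 4 (within the scatter), so this step, like the earlier one, cannot be told apart from repeated-measurement scatter. Set side by side, the two steps do not differ, and as far as these four compounds go, the change carries from one core to the other with no distinguishable difference: the same change on two cores in this assay, no change at the digits printed (within the scatter) from compound 1 to compound 2 and a number 7.2 percentage points higher (within the scatter) from compound 3 to compound 4, 7.2 percentage points apart, within the scatter of two such steps. Going by these compounds alone, this does not show that the change has no effect or that the two cores respond to it identically in general, and with only two pairs, each read at a single concentration, it gives no information about potency or about how the change would behave on a compound showing much more inhibition.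

The compounds shown leave open what fluoro, iodo, methyl, methoxy or a nitrile would do in the place held by chloro and bromo, and whether the same comparison would hold for them on both cores. They also leave open what would follow if the free amine gave way to an amide or the carbonyl to a methylene, since every compound here carries both the amine and the ketone.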